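Swapping a Chlorophenyl for Thiophene on a Receptor Agonist

A few compounds are considered here, and "the series" means these few. Any claim that something is new, unique, unknown or untested is made for them only; others in the source may bear on it.

Three measured compounds share one core. Compound 1 `O=C(O)CCc1ccc(OCc2nc(-c3cccs3)no2)cc1` carries a thiophen-2-yl group on that core, while compound 2 `O=C(O)CCc1ccc(OCc2nc(-c3ccc(Cl)cc3)no2)cc1` and compound 3 `CC(Oc1ccc(CCC(=O)O)cc1)c1nc(-c2ccc(Cl)cc2)no1` carry a 4-chlorophenyl group. In a functional assay on CHO cells for agonist activity at Free fatty acid receptor 1 (Homo sapiens), read by FLIPR and calcium flux, in the presence of a further agent that is not named here (a lower number here means that less compound is needed, a higher number that more compound is needed for the effect), compound 1 gives 2570 nM. In the same setting compound 2 gives 540 nM, and compound 3 gives 500 nM.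

Two changes separate these compounds. The first is thiophen-2-yl in place of 4-chlorophenyl on an aromatic carbon, which produced a 4.8-fold higher number from compound 2 to compound 1 (0.68 log units; beyond the scatter). The second is the difference between the cores of compound 2 and compound 3, namely (methyl in place of hydrogen on a saturated chain carbon bound to an aromatic carbon and an oxygen on an aromatic ring), which produced only a 1.1-fold lower number from compound 2 to compound 3 (0.03 log units; within the scatter), so these two compounds cannot be told apart in this assay.

Compound 4 `CC(Oc1ccc(CCC(=O)O)cc1)c1nc(-c2cccs2)no1` has not yet been measured. It differs from compound 3 by thiophen-2-yl in place of 4-chlorophenyl on an aromatic carbon. Among the compounds with values here, this is the same change as the one from compound 2 to compound 1, made at the same place on the same kind of ring, only on the core that carries the methyl group. The expectation is that it behaves as before: a step of a 4.8-fold higher number from compound 3 to compound 4 (0.68 log units; beyond the scatter) is estimated, because the earlier step of a 4.8-fold higher number from compound 2 to compound 1 (0.68 log units; beyond the scatter) lay well beyond the scatter and because the core difference a 1.1-fold lower number from compound 2 to compound 3 (0.03 log units; within the scatter) did not move the number. Compound 4 is therefore expected to give about 2400 nM in this assay, most likely between 1200 nM and 5000 nM.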

Compound 4, half-maximal effective concentration: 4000 nM
Estimate against measurement, compound 4: 1.7-fold (0.22 log units) below; the range from low to high includes it.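

On the core that carries the methyl group, thiophen-2-yl in place of 4-chlorophenyl gave an 8.0-fold higher number from compound 3 to compound 4 (0.90 log units; beyond the scatter) in this assay, and the two steps for this swap agree, so in this pair of cores the penalty of leaving 4-chlorophenyl carried over from one core to the other: the same change on two cores in this assay, a 4.8-fold higher number (0.68 log units; beyond the scatter) from compound 2 to compound 1 and an 8.0-fold higher number (0.90 log units; beyond the scatter) from compound 3 to compound 4, 1.7-fold (0.23 log units) apart, within the scatter of two such steps. The methyl group also made no readable difference once the thiophen-2-yl group was in place, with a 1.6-fold higher number from compound 1 to compound 4 (0.19 log units; within the scatter), and this matches what it did with 4-chlorophenyl on the ring: the same change on two cores in this assay, a 1.1-fold lower number (0.03 log units; within the scatter) from compound 2 to compound 3 and a 1.6-fold higher number (0.19 log units; within the scatter) from compound 1 to compound 4, 1.7-fold (0.23 log units) apart, within the scatter of two such steps. Within the data shown here, this shows that the two changes act independently of each other within these four compounds, but it rests on only two cores that differ by one methyl group in a single assay, so it does not show that the swap would behave the same way on a core changed elsewhere, and it does not explain why the number rises.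

As far as these compounds go, it remains open whether other groups in the same place, such as 4-fluorophenyl or furan-2-yl, would keep the lower numbers seen with 4-chlorophenyl. From the compounds shown here alone, it is also open whether an ethyl group or a longer chain in place of the methyl group would stay as silent as the methyl group did here.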